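This account rests on a few compounds, and the source may have more. Where it says the series, first, only, none or still open, it means among the compounds named here.

Measured so far in a functional assay on A549 cells (Homo sapiens) for inhibition, read by MTT assay, with a stated time of 48 h; on this read-out lower numbers stand for stronger inhibition and higher numbers for weaker inhibition:
- compound 1, `CCOC(=O)c1cc(-c2ccccc2)nn1CC(O)COc1ccccc1`: 65000 nM
- compound 2, `CCOC(=O)c1cc(-c2ccccc2)nn1CC(O)COc1ccc([N+](=O)[O-])cc1`: 48000 nM
- compound 3, `CCOC(=O)c1cc(-c2ccccc2)nn1CC(O)COc1ccccc1[N+](=O)[O-]`: 30000 nM

Compound 1 gives the highest of the three numbers in this assay. The step of a 1.4-fold lower number from compound 1 to compound 2 (0.13 log units; within the scatter) stays within the scatter; the step of a 2.2-fold lower number from compound 1 to compound 3 (0.34 log units; beyond the scatter) is a modest one beyond it; the step of a 1.6-fold lower number from compound 2 to compound 3 (0.20 log units; within the scatter) again stays within the scatter. All three numbers sit close together.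

Compound 4, `CCOC(=O)c1cc(-c2ccc(OC)cc2)nn1CC(O)COc1ccccc1`, differs from compound 1 by methoxy in place of hydrogen on an aromatic carbon. The measured steps all concern the phenoxy part of the molecule, where a nitro enters; none touches the phenyl on the shared core, where the methoxy enters here. So no measured step bears directly on this change, and the modest spread seen among compounds 1, 2 and 3 is the only guide to how far a single substituent on a ring can move the number in this series.

The expectation is therefore a step of a 1.1-fold lower number from compound 1 to compound 4 (0.03 log units; within the scatter), not beyond the scatter. Compound 4 is estimated at 60000 nM in this assay, with a range from 30000 nM to 120000 nM.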

Compound 4, half-maximal inhibitory concentration: 33000 nM
Compound 4: middle estimate off by 1.8-fold (0.26 log units), on the high side; the measured number falls inside the stated range.
By their numbers in this assay, from the lowest: compounds 3, 4, 2 and 1 (each within the scatter of the next, the first and the last beyond it).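

In this assay, the phenyl on the shared core can now be read as well as the phenoxy part: methoxy in place of hydrogen, para to a large group, gives a 2.0-fold lower number from compound 1 to compound 4 (0.29 log units; within the scatter) and so stays within the scatter. A substituent on this ring therefore leaves compound 4 within the scatter of compound 1, and the step does not open a new range of numbers for the series. Nothing measured here accounts for the size of this step.

Open at this position are groups other than methoxy, such as an amine or a carboxylic acid, and whether methoxy on this ring combines with a nitro on the phenoxy ring. The ethyl ester stands unchanged in all four compounds, so the effect of an amide in its place also remains unread.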